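Moving the chlorine on the amide-side ring: cytotoxicity outlook

The source may hold more compounds than are shown below. What is called first, only, known or untested is meant among the compounds shown, and "the series" means these compounds.

Measured so far:
- compound 1, `CC1=C(C(=O)Nc2ccccc2Cl)C(c2ccccc2Cl)NC(=O)N1`: "non-toxic" (no number reported)
- compound 2, `CC1=C(C(=O)Nc2ccccc2Cl)C(c2cnc(CS)n2Nc2ccccc2)NC(=O)N1`: > 100000 nM

Of the compounds shown here, two have been tested in an ADME assay on Vero cells (Chlorocebus sabaeus) for cytotoxicity, read by XTT assay, with a stated time of 72 h; on this read-out lower numbers stand for higher toxicity in this test and higher numbers for lower toxicity in this test. Compound 1, `CC1=C(C(=O)Nc2ccccc2Cl)C(c2ccccc2Cl)NC(=O)N1`, is recorded simply as "non-toxic" (no number reported), without a number. For compound 2, `CC1=C(C(=O)Nc2ccccc2Cl)C(c2cnc(CS)n2Nc2ccccc2)NC(=O)N1`, the read-out is a limit of the assay rather than a number: compound 2 gives > 100000 nM. This is the point where compound 2 stands, as the limit of > 100000 nM in this assay, at which 1 of the 2 values shown sits.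

Compound 3, `CC1=C(C(=O)Nc2ccc(Cl)cc2)C(c2cnc(CS)n2Nc2ccccc2)NC(=O)N1`, has not yet been measured. It differs from compound 2 in one place: 4-chlorophenyl in place of 2-chlorophenyl on an amide-type nitrogen whose other neighbour is a carbonyl carbon.

Going by the values given here, no step between measured compounds is available to guide the change. Given that compound 2 sits at > 100000 nM, the expectation for compound 3 is a step of a number no higher from compound 2 to compound 3 (the limit leaves the size open) in this assay, meaning none beyond the scatter. Compound 3 is therefore expected to give about 100000 nM, within 30000 nM to 300000 nM, most likely again reported only as a limit.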

Compound 3, half-maximal cytotoxic concentration: > 100000 nM
Compound 3 ended at the assay's limit; the forecaster's own chance of this, stated with the estimate: 85%; the middle value sits exactly at the limit.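

In this assay, no step can be read from compound 2 to compound 3, because each result is a limit and not a number: the limit of > 100000 nM in this assay, at which 2 of the 3 values shown sit.

The compounds shown leave open whether 4-chlorophenyl and 2-chlorophenyl on the amide-type nitrogen differ in cytotoxicity at all.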